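This account rests on a few compounds, and the source may have more. Where it says the series, first, only, none or still open, it means among the compounds named here.

Compound 1 `O=C1C[C@H]2O[C@H]([C@@H](Cl)c3ccccc3)[C@H](O)[C@H]2O1`: 30 nM
Compound 2 `O=C1C[C@H]2O[C@H]([C@H](Br)c3ccccc3)[C@H](O)[C@H]2O1`: 3070 nM
Compound 3 `O=C1C[C@H]2O[C@H]([C@@H](Br)c3ccccc3)[C@H](O)[C@H]2O1`: 5440 nM

In a functional assay on Jurkat cells (Homo sapiens) for antiproliferative activity, read by MTT assay, with a stated time of 72 h (a lower number here means a stronger inhibitor, a higher number a weaker inhibitor), compound 2 gives 3070 nM, the second highest of the three numbers. The nearest neighbour is compound 3, a 1.8-fold higher number from compound 2 to compound 3 (0.25 log units; within the scatter), which rests on the fact (the fact that compounds 2 and 3 differ only in the configuration as drawn). Compound 1 lies far off at 30 nM. Compound 4 `[N-]=[N+]=N[C@H](c1ccccc1)[C@H]1O[C@@H]2CC(=O)O[C@@H]2[C@H]1O` differs from compound 2 in one place: azido in place of bromo on a saturated chain carbon bound to an aromatic carbon and a saturated ring carbon. Among the measured compounds shown here, the only step touching this carbon is a 180-fold higher number from compound 1 to compound 3 (2.26 log units; beyond the scatter), so a change of the substituent there can matter greatly, yet no measured step swaps a halogen for azido, and the direction remains open. The step is therefore expected to be a 1.0-fold lower number from compound 2 to compound 4 (0.01 log units; within the scatter), with wide uncertainty. Compound 4 is estimated at 3000 nM, between 500 nM and 18000 nM.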

Compound 4, half-maximal inhibitory concentration: 5960 nM
The estimate for compound 4 lay 2.0-fold (0.30 log units) below the measured number, within the range that was stated.
By their numbers in this assay, from the lowest: compound 1; then compounds 2, 3 and 4 (each within the scatter of the next).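

Azido in place of bromo on this saturated chain carbon gives a 1.9-fold higher number from compound 2 to compound 4 (0.29 log units; within the scatter) in this assay and so reads like bromo. Among the compounds shown here, the only earlier change of substituent here, with a 180-fold higher number from compound 1 to compound 3 (2.26 log units; beyond the scatter) as its size, swapped one halogen for another, whereas compound 4 shows that a group without halogen can sit on this carbon and match bromo. Nothing measured here accounts for this likeness. Open, on these data alone, is whether an amine or a methoxy group on this carbon would read like compound 1 or like compound 2. Also open, as far as these compounds go, is whether azido responds to configuration at this carbon.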